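The source may hold more compounds than are shown below. What is called first, only, known or untested is meant among the compounds shown, and "the series" means these compounds.

Measured so far:
compound 1 `COc1ccc2c(c1)SCC(=O)N2` — 21100 nM
compound 2 `O=C1CSc2cc(OCC3CCCCC3)ccc2N1` — 1170 nM

Notes on the series. The read-out is an assay on isolated protein for inhibition of Amine oxidase [flavin-containing] A (Homo sapiens), read by fluorescence and spectrophotometry, with a stated time of 20 min; on this read-out higher numbers stand for weaker inhibition and lower numbers for stronger inhibition. Compound 1 `COc1ccc2c(c1)SCC(=O)N2` is the weaker of the two measured inhibitors in this assay and gives 21100 nM, the higher of the two numbers; its nearest neighbour is compound 2 `O=C1CSc2cc(OCC3CCCCC3)ccc2N1`, which gives 1170 nM.

The next compound, compound 3 `O=C1CSc2cc(O)ccc2N1`, differs from compound 1 by hydrogen in place of methyl on an oxygen on an aromatic ring; cut one bond further out, the change reads methoxy to hydroxy.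

Among the compounds with values here, only one measured step touches the same position. The step of an 18-fold lower number from compound 1 to compound 2 (1.26 log units; beyond the scatter) placed cyclohexyl where compound 1 has hydrogen on the saturated chain carbon bound to that oxygen, and the number fell sharply. Compound 3 goes the other way, removing that carbon altogether. Within the data shown here, on the two numbers known, the larger group at this oxygen gave the stronger inhibition and the smaller one the weaker; nothing is known about the bare hydroxy. The step from compound 1 to compound 3 is therefore expected to be toward a higher number, a 1.7-fold higher number from compound 1 to compound 3 (0.22 log units; within the scatter), or at most to stay within the scatter of compound 1. For compound 3 the estimate in this assay is 35000 nM, within 15000 nM to 90000 nM.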

Compound 3, half-maximal inhibitory concentration: 19200 nM
The estimate for compound 3 lay 1.8-fold (0.26 log units) above the measured number; the measured number falls inside the stated range.
By their numbers in this assay, from the lowest: compound 2; then compounds 3 and 1 (each within the scatter of the next).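

In this assay the change from methoxy to hydroxy gives a 1.1-fold lower number from compound 1 to compound 3 (0.04 log units; within the scatter) and so leaves the number within the scatter. The methyl on this oxygen therefore makes no measurable difference, whereas the earlier step, an 18-fold lower number from compound 1 to compound 2 (1.26 log units; beyond the scatter), showed only that cyclohexyl on the saturated chain carbon goes with a large change. Among the three compounds, the step to compound 2 is thus the only one at this oxygen that lies beyond the scatter, and no measured evidence accounts for either result.

Going by these compounds, what remains open is how much of the step to compound 2 depends on the cyclohexyl ring itself and how much on the overall size of the group on the oxygen, a question that a straight butyl chain or a phenyl ring in its place would address. The compounds shown also leave open how this assay responds to an amine or a carboxylic acid at the end of a chain on the same oxygen.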